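Swapping the aryl group on the carbonyl of compound 3

The compounds below may be only part of what the source reports. "The series", "measured", "known", "first", "only" and "open" are said of these compounds alone.

Compound 3 `CN(C)c1ccc(C2CC(c3ccc(-n4cncn4)cc3)=NN2C(=O)c2cc(Cl)cc(Cl)c2)cc1` gives 5.3% in a functional assay on HCC1806 cells (Homo sapiens) for inhibition, read by sulforhodamine B assay, tested at 10 uM (on this read-out higher numbers stand for more inhibition at the one concentration tested (going by the name of the read-out) and lower numbers for less inhibition), second highest of the three numbers. Compound 2 `CN(C)c1ccc(C2CC(c3ccc(-n4cncn4)cc3)=NN2C(=O)CCCl)cc1` gives -3.4%, and compound 1 `CN1CCN(c2ccc(C3=NN(C(=O)c4ccc(C(F)(F)F)cc4)C(c4ccc(N(C)C)cc4)C3)cc2)CC1` gives 84.1%. Compound 4 `CN(C)c1ccc(C2CC(c3ccc(-n4cncn4)cc3)=NN2C(=O)c2ccc(C(F)(F)F)cc2)cc1` is not yet measured; it carries 4-(trifluoromethyl)phenyl in place of 3,5-dichlorophenyl on a carbonyl carbon. Within the data shown here, the one measured step that touches this carbonyl position, a number 8.7 percentage points higher from compound 2 to compound 3 (within the scatter), was small. Compound 1 carries the entering group but differs from compound 3 elsewhere as well, so its high number cannot be tied to this group alone. A small step, none beyond the scatter, is therefore expected as a number 6.7 percentage points higher from compound 3 to compound 4 (within the scatter). Compound 4 is estimated at 12%, with a range from -8% to 40%.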

Compound 4, a percentage reported as inhibition, at one concentration (the size of the read-out at that concentration, not a potency): 7%
The estimate for compound 4 lay 5 percentage points above the measured number; the measured number falls inside the stated range.
By their numbers in this assay, from the lowest: compounds 2, 3 and 4 (each within the scatter of the next, the first and the last beyond it); then compound 1.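

In this assay the change on the carbonyl carbon stays small, with a number 1.7 percentage points higher from compound 3 to compound 4 (within the scatter) for 4-(trifluoromethyl)phenyl in place of 3,5-dichlorophenyl, while 4-(trifluoromethyl)phenyl in place of 2-chloroethyl gives a number 10.4 percentage points higher from compound 2 to compound 4 (beyond the scatter) and is only modest. The far larger change lies elsewhere: with the carbonyl group held the same, a number 77.1 percentage points lower from compound 1 to compound 4 (beyond the scatter) comes with 1H-1,2,4-triazol-1-yl in place of 4-methylpiperazin-1-yl on an aromatic carbon. Nothing measured here explains these steps.

From the compounds shown here alone, whether a morpholine or a simple primary amine on that aromatic carbon would keep the high number of compound 1 stays open. Also open, going by these compounds, is how much the group on the carbonyl carbon matters when 4-methylpiperazin-1-yl is present.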